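The source may report more compounds than this note shows. Statements on the series, on what has been measured and on what is new or still open speak of the compounds shown alone.

Compound 1, `Nc1nc(Cl)c2ncn(Cc3ccc(CCl)cc3)c2n1`, gives 15500 nM in a functional assay on OVCAR-4 cells (Homo sapiens) for cytotoxicity, read by sulforhodamine B assay, with a stated time of 48 h; a higher number here means a weaker inhibitor of growth, a lower number a stronger inhibitor of growth.
Compound 2, `ClCc1cccc(Cn2cnc3c(Cl)nc(Cl)nc32)c1`, gives 5490 nM in this assay.
Compound 3, `ClCc1ccc(Cn2cnc3c(Cl)nc(Cl)nc32)cc1`, gives 4900 nM in this assay.

Compound 2 and compound 3 are built from the same atoms joined differently; the difference between the two cores is not broken down here. Their numbers in this assay lie within the scatter of each other, so nothing separates them.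

Compound 1 arises from compound 3 by one change, (amino in place of chloro on an aromatic carbon). That step, a 3.2-fold higher number from compound 3 to compound 1 (0.50 log units; beyond the scatter), is the only measured effect of this change.

Compound 4, `Nc1nc(Cl)c2ncn(Cc3cccc(CCl)c3)c2n1`, has not yet been measured. It arises from compound 2 by the same change, (amino in place of chloro on an aromatic carbon), made at the same place. Going by the values given here, because the step of a 3.2-fold higher number from compound 3 to compound 1 (0.50 log units; beyond the scatter) is the single precedent, and because compound 2 and compound 3 sit so close in this assay, the step from compound 2 to compound 4 is expected to be about as large, a 3.1-fold higher number from compound 2 to compound 4 (0.49 log units; beyond the scatter). Compound 4 is therefore estimated at 17000 nM in this assay, most likely between 8500 nM and 35000 nM.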

Compound 4, concentration for 50% growth inhibition: 1950 nM
Beside the measured number, compound 4's estimate is 8.7-fold (0.94 log units) above it; the whole stated range lies above it.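

The same swap of amino for chloro, on the aromatic carbon between two ring nitrogen atoms, gives a 2.8-fold lower number from compound 2 to compound 4 (0.45 log units; beyond the scatter) in this assay, so the size and direction of the earlier step did not carry over, and the two results disagree: the same change on two cores in this assay, a 3.2-fold higher number (0.50 log units; beyond the scatter) from compound 3 to compound 1 and a 2.8-fold lower number (0.45 log units; beyond the scatter) from compound 2 to compound 4, 8.9-fold (0.95 log units) apart, beyond the scatter of two such steps
In this small series, then, the effect of this change depends on the core that carries it, and a step measured on one core is a poor guide to the same step on another. Two pairs cannot show which difference between the cores is responsible, or how the change would behave on any further core.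

The compounds shown leave open how a different group on that carbon, such as methoxy or methylamino, would behave on each core. They also leave open whether a longer chain in place of the chloromethyl group would alter the effect of the amino-for-chloro swap.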